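Carrying the 2-chlorobenzyl to 3,5-dimethylbenzyl exchange onto compound 3

The source may report more compounds than this note shows. Statements on the series, on what has been measured and on what is new or still open speak of the compounds shown alone.

Compound 1 `Cc1ccccc1-c1c(C(=O)N(C)Cc2ccccc2Cl)n(C)c(=O)c2ccccc12` is the reference for the first pair. In an assay on IM-9 cells for binding affinity to Substance-P receptor (Homo sapiens) (a lower number here means a stronger inhibitor, a higher number a weaker inhibitor), compound 1 gives 19 nM. Compound 2 `Cc1cc(C)cc(CN(C)C(=O)c2c(-c3ccccc3C)c3ccccc3c(=O)n2C)c1` differs from it by 3,5-dimethylphenyl in place of 2-chlorophenyl on a saturated chain carbon bound to an amide-type nitrogen, and in this assay compound 2 gives 32 nM. The difference between the two is a 1.7-fold higher number from compound 1 to compound 2 (0.23 log units; within the scatter). Compound 3 `Cc1cc2c(-c3ccccc3)c(NC(=O)N(C)Cc3ccccc3Cl)n(C)c(=O)c2cc1C` carries a different core; how it differs from compound 1 is not broken down here. In this assay compound 3 gives 4.2 nM, the lowest of the three numbers and beyond the scatter from both others. Compound 4 `Cc1cc(C)cc(CN(C)C(=O)Nc2c(-c3ccccc3)c3cc(C)c(C)cc3c(=O)n2C)c1` is not yet measured; it differs from compound 3 by 3,5-dimethylphenyl in place of 2-chlorophenyl on a saturated chain carbon bound to an amide-type nitrogen, the same change as that from compound 1 to compound 2, at the same place. Within the data shown here, only one earlier instance of this change exists, so the expectation rests on compound 1 alone through a 1.7-fold higher number from compound 1 to compound 2 (0.23 log units; within the scatter). A step of about that size is expected from compound 3 to compound 4, a 1.7-fold higher number from compound 3 to compound 4 (0.22 log units; within the scatter). For compound 4 the estimate in this assay is 7 nM, with a likely range from 3 nM to 16 nM.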

Compound 4, half-maximal inhibitory concentration: 28 nM
The estimate for compound 4 lay 4.0-fold (0.60 log units) below the measured number; measured number above the stated range.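

In this assay, replacing 2-chlorobenzyl with 3,5-dimethylbenzyl gives a 6.7-fold higher number from compound 3 to compound 4 (0.82 log units; beyond the scatter), so on the core of compound 3 this exchange costs clearly measurable potency. The exchange therefore does not carry over at one size from the core of compound 1 to the core of compound 3: the same change on two cores in this assay, a 1.7-fold higher number (0.23 log units; within the scatter) from compound 1 to compound 2 and a 6.7-fold higher number (0.82 log units; beyond the scatter) from compound 3 to compound 4, 4.0-fold (0.60 log units) apart, beyond the scatter of two such steps Compound 1 and compound 3 differ in more than one place, so these two pairs do not show which part of the core sets the size of the step, and they give no rule for any further core.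

From the compounds shown here alone, it remains open whether an unsubstituted benzyl, or a benzyl bearing trifluoromethyl or methoxy groups, would show the same dependence on the core in this assay. Also open, going by these compounds, is how large the step would be on a core carrying only one of the differences between compound 1 and compound 3.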